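The source may report more compounds than this note shows. Statements on the series, on what has been measured and on what is new or still open speak of the compounds shown alone.

Compound 1 `O=C(/C=C1\CCc2cc(Cl)ccc21)NC1CC1`: 34%
Compound 2 `NC(=O)/C=C1\CCc2cc(Cl)ccc21`: 30%
Compound 3 `NC(=O)/C=C1\CCc2ccc(Br)cc21`: 38%

In a functional assay on the whole organism with Rattus norvegicus as the target, at a dose of 20 mg/kg by the oral route (on this read-out higher numbers stand for more inhibition at the one dose given (going by the name of the read-out) and lower numbers for less inhibition), compound 1 gives 34%, compound 2 gives 30% and compound 3 gives 38%. The gaps between these three numbers all lie within the usual scatter of repeated measurements, so none of the three stands apart from the others. Compound 1 differs from compound 2 by cyclopropyl in place of hydrogen on an amide-type nitrogen, and this change gave a number 4 percentage points higher from compound 2 to compound 1 (within the scatter). How the core of compound 3 differs from the core of compound 2 is not broken down here. Compound 4 `O=C(/C=C1\CCc2ccc(Br)cc21)NC1CC1` has not yet been measured in this assay; it differs from compound 3 by cyclopropyl in place of hydrogen on an amide-type nitrogen, the same change as from compound 2 to compound 1. Because a number 4 percentage points higher from compound 2 to compound 1 (within the scatter) stayed within the scatter, compound 4 is expected to shift only slightly, by an estimated a number 4 percentage points higher from compound 3 to compound 4 (within the scatter). Compound 4 is therefore estimated at 42%, with a likely range from 26% to 58%.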

Compound 4, a percentage reported as inhibition, in the whole organism at one dose (the size of the read-out at that dose, not a potency): 29%
Estimate against measurement, compound 4: 13 percentage points above; low and high end bracket the measured number.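

In this assay, cyclopropyl in place of hydrogen on an amide-type nitrogen gave a number 9 percentage points lower from compound 3 to compound 4 (within the scatter). Set side by side, the steps on the two cores show no difference that can be told from the scatter: the same change on two cores in this assay, a number 4 percentage points higher (within the scatter) from compound 2 to compound 1 and a number 9 percentage points lower (within the scatter) from compound 3 to compound 4, 13 percentage points apart, within the scatter of two such steps. This shows that the change carried from one core to the other without a clear difference in outcome, but it does not show that the change has the same effect on both cores, or any real effect on either, and two pairs say nothing about other cores.

From the compounds shown here alone, whether another group on the amide nitrogen, such as methyl, a longer chain or a phenyl ring, would move the number beyond the scatter remains open.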